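A few compounds are considered here, and "the series" means these few. Any claim that something is new, unique, unknown or untested is made for them only; others in the source may bear on it.

Measured in a functional assay on cells (Cancer cell lines, Homo sapiens) for cytotoxicity, with a stated time of 48 h; a lower number here means a stronger inhibitor of growth, a higher number a weaker inhibitor of growth:

- compound 1, `COc1cc2c(/C=C3/C(=O)Nc4ccc(Cl)cc43)c(Cl)n(Cc3cc(OC)c(OC)c(OC)c3)c2cc1C`: 2340 nM
- compound 2, `COc1ccc2c(c1)/C(=C\c1c(Cl)n(Cc3cc(OC)c(OC)c(OC)c3)c3cc(C)c(OC)cc13)C(=O)N2`: 16200 nM
- compound 3, `COc1c(/C=C2/C(=O)Nc3ccc(Cl)cc32)c2ccccc2n1-c1ccccc1`: 5250 nM

Compound 1 and compound 2 differ only by methoxy in place of chloro on an aromatic carbon, and the step is a 6.9-fold higher number from compound 1 to compound 2 (0.84 log units; beyond the scatter). Among the compounds with values here, compound 3 carries a different core; the difference between the cores of compound 1 and compound 3 is not broken down here, and no step is given between them, so the two values simply stand as they are.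

Compound 4, `COc1ccc2c(c1)/C(=C\c1c(OC)n(-c3ccccc3)c3ccccc13)C(=O)N2`, is the unmeasured partner of compound 3, differing by methoxy in place of chloro on an aromatic carbon. The place of the change reads the same as for the pair compound 1 to compound 2, so this is the same change made on the second core. Because of a 6.9-fold higher number from compound 1 to compound 2 (0.84 log units; beyond the scatter), a step of similar direction and size is expected, a 6.1-fold higher number from compound 3 to compound 4 (0.78 log units; beyond the scatter). Compound 4 is therefore estimated at 32000 nM in this assay, expected between 11000 nM and 90000 nM.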

Compound 4, concentration for 50% growth inhibition: 980 nM
Beside the measured number, compound 4's estimate is 33-fold (1.51 log units) above it, outside the stated range (below it).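

In this assay, methoxy in place of chloro on an aromatic carbon gives a 5.4-fold lower number from compound 3 to compound 4 (0.73 log units; beyond the scatter), so the same change runs in opposite directions on the two cores: the same change on two cores in this assay, a 6.9-fold higher number (0.84 log units; beyond the scatter) from compound 1 to compound 2 and a 5.4-fold lower number (0.73 log units; beyond the scatter) from compound 3 to compound 4, 37-fold (1.57 log units) apart, beyond the scatter of two such steps

For these two pairs, the outcome of the change depends on the core, and one pair is a poor guide to the other. Which difference between the core of compound 1 and the core of compound 3 reverses the step is not shown, and neither is the reason for the reversal.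

Still open, as far as these compounds go, is whether an amine or a nitrile at this aromatic carbon would follow chloro or methoxy on either core. Also open, from the compounds shown here alone, is whether the reversal would hold on a third core.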